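Replacing a hydroxyalkyl chain with phenyl in a cytotoxicity series

A few compounds are considered here, and "the series" means these few. Any claim that something is new, unique, unknown or untested is made for them only; others in the source may bear on it.

Measured compounds: compound 1, `CSc1ccc(CNc2nc(SC)nc3ncccc23)cc1`, gives 600 nM; compound 2, `[SeH]c1nc(NCc2ccccc2)c2cccnc2n1`, gives 8400 nM; compound 3, `CSc1nc(NCCCCCO)c2cccnc2n1`, gives > 100000 nM.

In an ADME assay on BEAS-2B cells (Homo sapiens) for cytotoxicity, read by MTT assay, with a stated time of 72 h (on this read-out higher numbers stand for weaker inhibition of growth and lower numbers for stronger inhibition of growth), compound 3 reaches only a limit of the assay and no number, (the limit of > 100000 nM in this assay, at which 1 of the 3 values shown sits). Compound 4, `CSc1nc(NCc2ccccc2)c2cccnc2n1`, differs from compound 3 in one place: phenyl in place of 4-hydroxybutyl on a saturated chain carbon bound to a nitrogen on an aromatic ring. Compound 1 and compound 2 both carry a benzyl group on that nitrogen and both return numbers in this assay, whereas compound 3 with its 4-hydroxybutyl chain does not. On that basis he expects the step of an at least 20-fold lower number from compound 3 to compound 4 (1.30 log units; beyond the scatter) to go toward stronger inhibition of growth and to lie beyond the scatter. He estimates compound 4 at 5000 nM in this assay, within 1000 nM to 40000 nM.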

Compound 4, concentration for 50% growth inhibition: 25900 nM
Beside the measured number, compound 4's estimate is 5.2-fold (0.71 log units) below it; low and high end bracket the measured number.
By their numbers in this assay, from the lowest: compound 1; then compound 2; then compound 4. At a limit, above all of these: compound 3.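

In this assay, phenyl in place of 4-hydroxybutyl at this position yields a number at all, with an at least 3.8-fold lower number from compound 3 to compound 4 (0.58 log units; beyond the scatter). Compound 3 stands at a limit, so that step is only a floor: the limit of > 100000 nM in this assay, at which 1 of the 4 values shown sits. With benzyl held on that nitrogen, the number still moves with changes elsewhere: a 3.1-fold higher number from compound 2 to compound 4 (0.49 log units; beyond the scatter) with a carbon and sulfur group in place of one selenium atom, and a 43-fold higher number from compound 1 to compound 4 (1.64 log units; beyond the scatter) with hydrogen in place of methylsulfanyl. Going by these compounds, the full size of the step from the chain to phenyl stays open. So does what an amine, a carboxylic acid or a longer chain on that nitrogen would give in this assay.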